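Replacing the heptafluoropropyl group of compound 2

The compounds below may be only part of what the source reports. "The series", "measured", "known", "first", "only" and "open" are said of these compounds alone.

In a functional assay on MCF7 cells (Homo sapiens) for antiproliferative activity (on this read-out higher numbers stand for weaker inhibition and lower numbers for stronger inhibition), compound 2 (`CCOC(=O)c1ccc2[nH]c3c(C(F)(F)C(F)(F)C(F)(F)F)c4[nH]c5ccc(C(=O)OCC)cc5c4cc3c2c1`) gives 90 nM as the only number shown. Compound 1 (`CN(C)C(=O)c1ccc2[nH]cc(Cc3c[nH]c4ccc(C(=O)N(C)C)cc34)c2c1`) returns > 10000 nM as a limit and not a number. Compound 3 (`CS(=O)(=O)c1ccc2[nH]cc(Cc3c[nH]c4ccc(S(C)(=O)=O)cc34)c2c1`) likewise returns > 10000 nM as a limit and not a number. Compound 4 (`CCOC(=O)Oc1c2[nH]c3ccc(C(=O)OCC)cc3c2cc2c1[nH]c1ccc(C(=O)OCC)cc12`) differs from compound 2 in one place, on an aromatic carbon, where (ethoxycarbonyl)oxy stands in place of 1,1,2,2,3,3,3-heptafluoropropyl: (ethoxycarbonyl)oxy in place of 1,1,2,2,3,3,3-heptafluoropropyl on an aromatic carbon. Going by the values given here, no measured pair isolates this exchange, so the expectation is tentative. A weakening beyond the scatter is expected in this assay, and the estimated size is a 5.6-fold higher number from compound 2 to compound 4 (0.74 log units; beyond the scatter). The estimate for compound 4 is 500 nM, within an expected range of 90 nM to 4000 nM.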

Compound 4, half-maximal inhibitory concentration: 110 nM
The estimate for compound 4 lay 4.5-fold (0.66 log units) above the measured number; the measured number falls inside the stated range.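

In this assay, going by these compounds alone, the exchange of 1,1,2,2,3,3,3-heptafluoropropyl for (ethoxycarbonyl)oxy on this aromatic carbon gives a 1.2-fold higher number from compound 2 to compound 4 (0.09 log units; within the scatter) and is the first step seen at this position. The position therefore accepts both groups, although the entering one has fewer heavy atoms and brings 3 hydrogen-bond acceptors where the leaving one has none. Going by these compounds, whether an amine or a carboxylic acid on this aromatic carbon would keep the number in this assay remains open. Nothing shown here gives a cause for this result.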